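From compound 3 to compound 4: a chlorinated replacement

This account rests on a few compounds, and the source may have more. Where it says the series, first, only, none or still open, it means among the compounds named here.

In a functional assay on PC-3 cells (Homo sapiens) for inhibition, read by sulforhodamine B assay (on this read-out lower numbers stand for stronger inhibition of growth and higher numbers for weaker inhibition of growth), compound 1 `FC(F)(F)Oc1ccc(-c2ccc(-c3ccc(-c4nc5ccccc5[nH]4)cc3)cc2)cc1` gives 100000 nM as its value. Compound 2 `Oc1cccc2[nH]c(-c3ccc(-c4ccc(-c5ccccc5)cc4)cc3)nc12` gives 1240 nM as its value, and compound 3 `Oc1cccc2[nH]c(-c3ccc(-c4ccc(-c5ccc(OC(F)(F)F)cc5)cc4)cc3)nc12` gives 7410 nM as its value, the second highest of the three numbers. Compound 4 `Oc1cccc2[nH]c(-c3ccc(-c4ccc(-c5cccc(Cl)c5)cc4)cc3)nc12` differs from compound 3 by 3-chlorophenyl in place of 4-(trifluoromethoxy)phenyl on an aromatic carbon and so carries 3-chlorophenyl in place of 4-(trifluoromethoxy)phenyl on an aromatic carbon. Two measured steps are available. The large step of a 13-fold lower number from compound 1 to compound 3 (1.13 log units; beyond the scatter) concerns hydroxy, which stays in place here, so it bears only weakly on this change. The modest step of a 6.0-fold higher number from compound 2 to compound 3 (0.78 log units; beyond the scatter) bears more directly, since compound 4 no longer carries trifluoromethoxy. Going by the values given here, no chlorinated compound has been measured, so the size remains uncertain. A modest move towards a lower number is expected, part of the way back towards compound 2. The expected step is a 2.5-fold lower number from compound 3 to compound 4 (0.39 log units; beyond the scatter) in this estimate. In this assay compound 4 is expected at 3000 nM with a range from 1000 nM to 9000 nM as its estimated span.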

Compound 4, concentration for 50% growth inhibition: 2560 nM
Compound 4: middle estimate off by 1.2-fold (0.07 log units), on the high side, within the range that was stated.
By their numbers in this assay, from the lowest: compound 2; then compound 4; then compound 3; then compound 1.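

In this assay, 3-chlorophenyl in place of 4-(trifluoromethoxy)phenyl gives a 2.9-fold lower number from compound 3 to compound 4 (0.46 log units; beyond the scatter) and shows that the number at this position moves with the choice of substituted phenyl group, not only with the loss or gain of trifluoromethoxy. The added chloro still gives a 2.1-fold higher number from compound 2 to compound 4 (0.31 log units; beyond the scatter) and leaves compound 2, with its unsubstituted phenyl, lowest among the hydroxy-bearing compounds, with both substituted versions higher. No measurement at hand accounts for either step.

The change from compound 3 to compound 4 alters both the substituent and its place on the phenyl ring, so the two contributions cannot be separated here. On these data alone, whether an amine or a carboxylic acid on that phenyl ring would give a number lower than that of compound 2 stays open.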